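Carbamoyl to methyl: an estimate for compound 4

The source may report more compounds than this note shows. Statements on the series, on what has been measured and on what is new or still open speak of the compounds shown alone.

Compound 1 `COc1ccc(/C=C2\c3cc(OC)c(OC)c(OC)c3CC[C@@H]2O)cc1C`: 2560 nM
Compound 2 `COc1ccc(/C=C2\c3cc(OC)c(OC)c(OC)c3CC[C@H]2O)cc1N`: 910 nM
Compound 3 `COc1ccc(/C=C2\c3cc(OC)c(OC)c(OC)c3CC[C@H]2O)cc1C(N)=O`: 550 nM

In a functional assay on HT-29 cells (Homo sapiens) for inhibition, read by MTT assay (on this read-out lower numbers stand for stronger inhibition and higher numbers for weaker inhibition), compound 3 gives 550 nM. That sits within the usual scatter of compound 2, at 910 nM, while compound 1 shows a clearly higher number, 2560 nM.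

Compound 4 `COc1ccc(/C=C2\c3cc(OC)c(OC)c(OC)c3CC[C@H]2O)cc1C` has methyl in place of carbamoyl on an aromatic carbon, ortho to a methoxy group (methyl in place of carbamoyl on an aromatic carbon). One measured step changes this same carbon, swapping amino for carbamoyl: a 1.7-fold lower number from compound 2 to compound 3 (0.22 log units; within the scatter). That is a small step, and it does not involve methyl. Among the measured compounds shown here, the only measured compound with methyl there is compound 1, at 2560 nM, but it differs from compound 4 in the handedness of the carbon carrying the hydroxyl, so it offers only a weak hint.

A modest move towards weaker inhibition is therefore expected, and the estimated change is a 1.8-fold higher number from compound 3 to compound 4 (0.26 log units; within the scatter). The estimated value for compound 4 is 1000 nM, with an expected range of 350 nM to 2800 nM.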

Compound 4, half-maximal inhibitory concentration: 3970 nM
For compound 4 the middle estimate is 4.0-fold (0.60 log units) below the measured one; measured number above the stated range.
By their numbers in this assay, from the lowest: compounds 3 and 2 (each within the scatter of the next); then compounds 1 and 4 (each within the scatter of the next).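

Swapping carbamoyl for methyl on this aromatic carbon is a real change in this assay and gives a 7.2-fold higher number from compound 3 to compound 4 (0.86 log units; beyond the scatter). Methyl also separates from amino, with a 4.4-fold higher number from compound 2 to compound 4 (0.64 log units; beyond the scatter), whereas amino and carbamoyl stay within the scatter of each other, so on this evidence methyl stands apart from both. The handedness of the carbon carrying the hydroxyl shows no change beyond the scatter in the methyl pair, with a 1.6-fold higher number from compound 1 to compound 4 (0.19 log units; within the scatter), and this comparison isolates that one feature: the fact that compounds 1 and 4 differ only in the configuration as drawn.

Only methyl is shown in both handed forms, so whether amino or carbamoyl would also tolerate the switch stays open. Going by these compounds, how a carboxylic acid, a dimethylamino group or a longer chain such as ethyl would read on this carbon also remains open.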